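Aryl ether in place of aryl thioether: compound 3

The source may hold more compounds than are shown below. What is called first, only, known or untested is meant among the compounds shown, and "the series" means these compounds.

The series shares one core. Compound 1 `COc1ccc(Sc2nc3cc(N)cc(N)c3nc2-c2ccccc2)cc1` carries a 4-methoxyphenyl on a sulfur, and in a functional assay on HOP-62 cells (Homo sapiens) for inhibition, read by sulforhodamine B assay, with a stated time of 48 h (a lower number here means that less compound is tolerated, a higher number that more compound is tolerated), compound 1 gives only a limit, < 100000 nM. Compound 2 `Nc1cc(N)c2nc(-c3ccccc3)c(Sc3ccc(Cl)c(Cl)c3)nc2c1` has 3,4-dichlorophenyl in place of 4-methoxyphenyl on that sulfur; in this assay compound 2 likewise gives only a limit, < 100000 nM. The step that the two limits leave unreadable from compound 1 to compound 2 has no readable size. For the measured compounds named here, compound 2 therefore stands at a limit rather than at a number, and the one further value shown is a limit as well; the limit of < 100000 nM in this assay, at which 2 of the 2 values shown sit, sums up the measured picture.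

Compound 3 `Nc1cc(N)c2nc(-c3ccccc3)c(Oc3ccc(F)cc3)nc2c1` brings the next change: 4-fluorophenoxy in place of (3,4-dichlorophenyl)sulfanyl on an aromatic carbon. No measured step bears directly on this exchange, and the only step shown, a step that the two limits leave unreadable from compound 1 to compound 2, is unreadable, so neither a direction nor a size beyond the scatter can be drawn from it for this assay. The expectation for compound 3 is carried over from compound 2 with wide uncertainty, and a limit rather than a number is the likeliest outcome. Compound 3 is estimated at 50000 nM (range 8000 nM to 100000 nM), an expected step that the limit leaves unreadable from compound 2 to compound 3.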

Compound 3, concentration lethal to 50% of the cells: < 100000 nM
Compound 3 was reported as a limit; the forecaster's own chance of this, stated with the estimate: 70%; the middle value does not contradict the limit.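

In this assay, for the compounds shown here, compound 3 gives < 100000 nM as a limit, so no step from compound 1 or compound 2 to compound 3 can be read. The compounds shown leave open whether either 4-fluorophenoxy in place of a arylsulfanyl group or 3,4-dichlorophenyl in place of 4-methoxyphenyl on the sulfur alters the value in this assay at all, with no compound here giving a number.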